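From a Methyl to a Methoxy on the Aryl Ring

The compounds below may be only part of what the source reports. "The series", "measured", "known", "first", "only" and "open" are said of these compounds alone.

Measured in a functional assay on T47D cells (Homo sapiens) for antiproliferative activity, read by MTT assay, with a stated time of 72 h; a higher number here means a weaker inhibitor, a lower number a stronger inhibitor:
- Compound 1 `CCCn1ccnc1-c1cc(OC)c(OC)c(OC)c1`: > 100000 nM (a limit of the assay)
- Compound 2 `COc1ccc(-n2ccnc2-c2cc(OC)c(OC)c(OC)c2)cc1[N+](=O)[O-]`: 10000 nM
- Compound 3 `COc1cc(-c2nccn2-c2ccc(C)cc2)cc(OC)c1OC`: 20500 nM

Compound 3, at 20500 nM, gives the higher of the two actual numbers, against compound 2 at 10000 nM. The result for compound 1 is only a limit.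

Compound 4 `COc1ccc(-n2ccnc2-c2cc(OC)c(OC)c(OC)c2)cc1` differs from compound 3 in one place, with methoxy in place of methyl on an aromatic carbon, para to a large group: methoxy in place of methyl on an aromatic carbon.

For the measured compounds named here, only one measured step comes close: an at least 4.8-fold lower number from compound 1 to compound 3 (0.68 log units; beyond the scatter). It concerns the group on the aromatic nitrogen as a whole, so it says little about a change on the 4-methylphenyl itself. Compound 2, which also carries a methoxy on its aromatic ring alongside a nitro group, reads 10000 nM. A small move toward a lower number is therefore expected, close to the scatter of this assay. The expected step is a 1.5-fold lower number from compound 3 to compound 4 (0.17 log units; within the scatter). Compound 4 is estimated at 14000 nM, with an expected range from 5000 nM to 40000 nM.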

Compound 4, half-maximal inhibitory concentration: 1400 nM
The estimate for compound 4 lay 10-fold (1.00 log units) above the measured number; measured number outside the range, below it.
By their numbers in this assay, from the lowest: compound 4; then compound 2; then compound 3. At a limit, above all of these: compound 1.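

In this assay the change from methyl to methoxy on an aromatic carbon, para to a large group, turns out to be far from minor (a 15-fold lower number from compound 3 to compound 4 (1.17 log units; beyond the scatter)), and the methoxy alone does not settle the number, since hydrogen in place of nitro also matters (a 7.1-fold lower number from compound 2 to compound 4 (0.85 log units; beyond the scatter)). The 4-methoxyphenyl also stands well apart from propyl on the aromatic nitrogen (an at least 71-fold lower number from compound 1 to compound 4 (1.85 log units; beyond the scatter)). Compound 1 gives only a limit, so that step has no fixed size: the limit of > 100000 nM in this assay, at which 1 of the 4 values shown sits.

The compounds shown leave open whether the lower number belongs to the methoxy itself or would also appear with an ethoxy, a hydroxyl or a fluorine at that place. As far as these compounds go, how an amine or a longer chain there would read also remains open.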